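Purine-like series: piperidinyl to benzylamino swap at the core

The source may hold more compounds than are shown below. What is called first, only, known or untested is meant among the compounds shown, and "the series" means these compounds.

Measured so far:
compound 1 `CCCSc1nc(N2CCCCC2)c2nc(/C=C/C(=O)c3ccc(C)cc3)n(Cc3ccccc3)c2n1` — 15700 nM
compound 2 `CCCSc1nc(Cl)c2c(n1)N(Cc1ccccc1)C(C(=O)NCCCc1ccccc1)N2` — 16900 nM

Both compounds were read in a functional assay on MGC-803 cells (Homo sapiens) for inhibition, read by MTT assay, with a stated time of 72 h; a higher number here means a weaker inhibitor, a lower number a stronger inhibitor. Compound 1 gives 15700 nM, the lowest of the two numbers. Compound 2, built on a different core, gives 16900 nM; the gap to compound 1 lies within the scatter, so the two cannot be ordered. For the measured compounds named here, no pair differing in a single place has been measured, so no step size is known from data.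

Compound 3 `CCCSc1nc(NCc2ccccc2)c2nc(/C=C/C(=O)c3ccc(C)cc3)n(Cc3ccccc3)c2n1` is the next candidate. It differs from compound 1 in one place: benzylamino in place of piperidin-1-yl on an aromatic carbon. Nothing measured speaks to whether a group of this kind at this site changes the read-out. Going by the values given here, with no comparable step on record and both measured compounds close together in this assay, the working expectation is a step from compound 1 to compound 3 of about a 1.2-fold lower number from compound 1 to compound 3 (0.08 log units; within the scatter), that is, no change beyond the scatter in either direction.

Compound 3 is therefore expected to give about 13000 nM in this assay, with a range from 4000 nM to 40000 nM.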

Compound 3, half-maximal inhibitory concentration: 12400 nM
Compound 3: middle estimate off by 1.0-fold (0.02 log units), on the high side, within the range that was stated.
By their numbers in this assay, from the lowest: compounds 3, 1 and 2 (each within the scatter of the next).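

In this assay, for the compounds shown here, benzylamino in place of piperidin-1-yl on the aromatic carbon of the shared core gives a 1.3-fold lower number from compound 1 to compound 3 (0.10 log units; within the scatter), the only step so far that isolates a single position. Going by these compounds alone, at this position, then, a non-aromatic ring without a hydrogen-bond donor can be exchanged for a benzylamino group, which carries an aromatic ring and a hydrogen-bond donor, with no shift beyond the scatter; the earlier compounds, which differ in more than one place, could not show this. No supporting measurement bears on why this exchange leaves the read-out within the scatter.

The compounds shown leave open whether this tolerance extends to groups of a different kind at the same carbon, such as an unsubstituted amine, a morpholin-4-yl ring, a carboxylic acid or a longer chain such as phenylpropylamino. They also leave open whether the same exchange would behave alike with the enone side chain of compound 1 replaced, since compound 2 differs from compound 1 and compound 3 in more than one place and offers no single-place comparison.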